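The compounds below may be only part of what the source reports. "The series", "measured", "known", "first", "only" and "open" are said of these compounds alone.

Measured so far in a functional assay on MGC-803 cells (Homo sapiens) for inhibition, read by MTT assay, with a stated time of 48 h; a lower number here means a stronger inhibitor, a higher number a weaker inhibitor: compound 1 `COc1cc(N(Cc2ccc(Cl)cc2)S(=O)(=O)c2ccc(C)cc2)cc(OC)c1OC` gives 1720 nM; compound 2 `COc1cc(N(Cc2ccccc2)S(=O)(=O)c2ccc(C)cc2)cc(OC)c1OC` gives 3570 nM; compound 3 `Cc1ccc(S(=O)(=O)N(Cc2nc3ccccc3[nH]2)c2ccc(Cl)cc2)cc1` gives 24800 nM.

Compound 3 stands furthest from compound 1 in this assay , and the difference between the two cores is not broken down here. Within the core of compound 1, the change hydrogen in place of chloro on an aromatic carbon gave a 2.1-fold higher number from compound 1 to compound 2 (0.32 log units; beyond the scatter).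

Compound 4 `Cc1ccc(S(=O)(=O)N(Cc2nc3ccccc3[nH]2)c2ccccc2)cc1` is not yet measured. It carries the same change on the core of compound 3: hydrogen in place of chloro on an aromatic carbon. The place reads the same in both cases, though cut one bond further out the first case also reads 4-chlorobenzyl to benzyl, which the second does not.

For compound 4 in this assay , a step of about a 1.8-fold higher number from compound 3 to compound 4 (0.26 log units; within the scatter) is expected, because the same change from compound 1 to compound 2 gave a 2.1-fold higher number from compound 1 to compound 2 (0.32 log units; beyond the scatter). Compound 4 is therefore estimated at 45000 nM, with a range from 18000 nM to 120000 nM.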

Compound 4, half-maximal inhibitory concentration: 45200 nM
Compound 4: middle estimate off by 1.0-fold (0.00 log units), on the low side; low and high end bracket the measured number.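

In this assay, hydrogen in place of chloro on the core of compound 3 reads a 1.8-fold higher number from compound 3 to compound 4 (0.26 log units; within the scatter). The two cores return steps that cannot be told apart: the same change on two cores in this assay, a 2.1-fold higher number (0.32 log units; beyond the scatter) from compound 1 to compound 2 and a 1.8-fold higher number (0.26 log units; within the scatter) from compound 3 to compound 4, 1.1-fold (0.06 log units) apart, within the scatter of two such steps. This agreement rests on two pairs only and does not establish a general rule for the series: the step on the core of compound 3 lies within the scatter on its own, and the chloro leaves a 4-chlorobenzyl group in one pair but a 4-chlorophenyl group in the other.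

Going by these compounds, whether a methoxy group or an amine at this place would track across the two cores in the same way remains open. Also open is what separates the two cores themselves, as no pair shown spans them with a single difference.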